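The source may hold more compounds than are shown below. What is called first, only, known or untested is meant among the compounds shown, and "the series" means these compounds.

Two compounds of the series have numbers in a functional assay on MCF7 cells (Homo sapiens) for cytotoxicity, read by MTT assay, with a stated time of 96 h; on this read-out higher numbers stand for weaker inhibition and lower numbers for stronger inhibition. Compound 1 `Cc1cc(CO)c2n1[C@@H](c1ccccc1)SC2` gives 19900 nM. Compound 2 `Cc1c(CO)cc2n1CSC2` gives 82300 nM, the highest of the two numbers, with compound 1 the nearest and the gap between the two beyond the scatter. Compound 3 `Cc1c(CO)c(CO)c2n1CSC2` is not yet measured and differs from compound 2 by hydroxymethyl in place of hydrogen on an aromatic carbon, a hydroxymethyl in place of hydrogen on an aromatic carbon. Among the measured compounds shown here, no step of this kind has been measured. The step of a 1.4-fold lower number from compound 2 to compound 3 (0.14 log units; within the scatter) is expected to stay within the scatter. For compound 3 the estimate in this assay is 60000 nM, in the range 20000 nM to 200000 nM.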

Compound 3, half-maximal inhibitory concentration: 21500 nM
Beside the measured number, compound 3's estimate is 2.8-fold (0.45 log units) above it; the measured number falls inside the stated range.
By their numbers in this assay, from the lowest: compounds 1 and 3 (each within the scatter of the next); then compound 2.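

In this assay, among the compounds shown here, hydroxymethyl in place of hydrogen on this aromatic carbon of the five-membered ring gives a 3.8-fold lower number from compound 2 to compound 3 (0.58 log units; beyond the scatter), the first step that can be read. The step is modest but beyond the scatter, so this position accepts the added hydroxymethyl with a lower number. Nothing available gives a reason for the step.

Still open, going by these compounds, is whether an amine, a carboxylic acid or a longer chain at this carbon would move the number the same way. On these data alone, whether the step carries over to the core of compound 1 is also open.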